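A few compounds are considered here, and "the series" means these few. Any claim that something is new, unique, unknown or untested is made for them only; others in the source may bear on it.

Measured in a functional assay on Caco-2 cells (Homo sapiens), read by MTT assay, with a stated time of 48 h; a higher number here means a weaker inhibitor, a lower number a stronger inhibitor:
- Compound 1 `CCn1c(C(=O)NCCN(C)C)ccc1C(CC)(CC)c1ccc(OCC(O)C(C)(C)C)c(C)c1`: 1300 nM
- Compound 2 `CCn1c(C(=O)NCCN)ccc1C(CC)(CC)c1ccc(OCC(O)C(C)(C)C)c(C)c1`: 1000 nM
- Compound 3 `C#CC(C)OC(=O)c1ccc(C(CC)(CC)c2ccc(OCC(O)C(C)(C)C)c(C)c2)n1CC`: > 50000 nM (a limit, not a number)

Compound 3 stands at the limit of > 50000 nM in this assay, at which 1 of the 3 values shown sits. Its true potency is therefore unknown, and any step away from it can only be read against that limit.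

Compound 4 `CCn1c(C(=O)N(C)CC(=O)O)ccc1C(CC)(CC)c1ccc(OCC(O)C(C)(C)C)c(C)c1` is still to be measured. It carries (carboxymethyl)(methyl)amino in place of (1-methylprop-2-yn-1-yl)oxy on a carbonyl carbon.

Going by the values given here, two measured steps bear most directly on this change. Both concern the same carbonyl carbon and both are large: an at least 38-fold higher number from compound 1 to compound 3 (1.58 log units; beyond the scatter) and an at least 50-fold higher number from compound 2 to compound 3 (1.69 log units; beyond the scatter). Compound 4 shares with compound 1 and compound 2 a nitrogen on that carbonyl, which argues for some recovery from compound 3 in this assay. However, the chain on that nitrogen differs, and no measured compound carries a carboxymethyl group. Among the compounds with values here, the only measured change at a chain end, a 1.3-fold lower number from compound 1 to compound 2 (0.11 log units; within the scatter), swaps amino for dimethylamino and says little about this group.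

Only partial recovery is therefore expected, with a lower number than compound 3 but well short of compound 1 and compound 2. The expected change is an at least 3.3-fold lower number from compound 3 to compound 4 (0.52 log units; beyond the scatter). For compound 4 the estimate is 15000 nM, with an expected range of 2500 nM to 50000 nM.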

Compound 4, half-maximal inhibitory concentration: 31900 nM
Compound 4: middle estimate off by 2.1-fold (0.33 log units), on the low side, within the range that was stated.
By their numbers in this assay, from the lowest: compounds 2 and 1 (each within the scatter of the next); then compound 4. At a limit, above all of these: compound 3.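

In this assay, a nitrogen on the carbonyl carbon is not enough on its own to hold the level of the two aminoethyl amides: (carboxymethyl)(methyl)amino in place of (2-aminoethyl)amino gives a 32-fold higher number from compound 2 to compound 4 (1.50 log units; beyond the scatter), and in place of (2-(dimethylamino)ethyl)amino it gives a 25-fold higher number from compound 1 to compound 4 (1.39 log units; beyond the scatter). The link between a nitrogen at this position and a low number therefore holds for compound 1 and compound 2 only, and compound 4 goes against it. The change from (1-methylprop-2-yn-1-yl)oxy can be read only as a floor, an at least 1.5-fold lower number from compound 3 to compound 4 (0.19 log units; that floor lies within the scatter), and it rests on a limit rather than a number: the limit of > 50000 nM in this assay, at which 1 of the 4 values shown sits.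

The compounds shown do not separate the contributions of the carboxylic acid, the methyl on the amide nitrogen and the loss of the chain-end amine, as compound 4 differs from compound 1 and compound 2 in all of these at once. A secondary amide carrying the carboxymethyl chain, a methyl ester in place of the carboxylic acid, or a longer chain ending in an amine would each address part of that question.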